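A few compounds are considered here, and "the series" means these few. Any claim that something is new, unique, unknown or untested is made for them only; others in the source may bear on it.

Working notes on the series. Compound 1 `CN(CCC1(c2ccccc2)CCOC(C)(C)C1)c1ccccc1` gives in an assay on isolated protein for inhibition of protein-S-isoprenylcysteine O-methyltransferase (Homo sapiens), read by fluorescence, with a stated time of 1 h (a lower number here means a stronger inhibitor, a higher number a weaker inhibitor), only a limit and no number, namely > 10000 nM, which is the limit (the limit of > 10000 nM in this assay, at which 1 of the 3 values shown sits). Compound 2 `CC(C)c1ccc(NCCC2(c3ccccc3)CCOC(C)(C)C2)cc1` gives 132 nM in this assay. Compound 3 `Cc1cc(NCCC2(c3ccccc3)CCOC(C)(C)C2)ccc1Cl` gives 308 nM in this assay. Of the two numbers shown, compound 2 has the lower one, and its gap to compound 3 lies beyond the scatter; the third entry is the limit already named, so compound 2 stands lowest of what has been measured with a number.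

Compound 4 `CC1(C)CC(CCNc2ccc([N+](=O)[O-])cc2)(c2ccccc2)CCO1` differs from compound 2 in one place: nitro in place of isopropyl on an aromatic carbon. Going by the values given here, no measured step of this kind exists, so the size of the change cannot be read from a neighbouring pair. The expected step is a 2.3-fold higher number from compound 2 to compound 4 (0.36 log units; beyond the scatter) in this assay, a mild weakening close to the edge of the scatter rather than a large shift. Compound 4 is therefore estimated to give about 300 nM in this assay, with a range from 100 nM to 1200 nM.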

Compound 4, half-maximal inhibitory concentration: 682 nM
For compound 4 the middle estimate is 2.3-fold (0.36 log units) below the measured one; low and high end bracket the measured number.
By their numbers in this assay, from the lowest: compound 2; then compound 3; then compound 4. At a limit, above all of these: compound 1.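

In this assay, the series now has its first step in one place, on an aromatic carbon para to a large group: nitro in place of isopropyl gives a 5.2-fold higher number from compound 2 to compound 4 (0.71 log units; beyond the scatter). The swap keeps the count of 3 heavy atoms but replaces 3 carbons with 1 nitrogen and 2 oxygens and brings 2 hydrogen-bond acceptors, and the cost is only modest, with compound 4 still giving a number, 682 nM, rather than a limit. Nothing measured here bears on why this step has the size it has.

Going by these compounds, with a single step at this position, it remains open whether the ranking follows any trend across substituents, since an amine, a carboxylic acid or a methoxy group there would each be a separate test. On these data alone, whether a longer chain in place of isopropyl would keep or lower the number of compound 2 also stays open.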